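The source may hold more compounds than are shown below. What is called first, only, known or untested is meant among the compounds shown, and "the series" means these compounds.

Two compounds share one core, on which a carbonyl carbon carries an aromatic ring. Compound 1 `COc1cc(-c2cc(/C=C/C(=O)c3ccc(N)cc3)[nH]n2)cc(OC)c1OC` carries a 4-aminophenyl there, while compound 2 `COc1ccc(-c2cc(/C=C/C(=O)c3ccc(OC)c(OC)c3)[nH]n2)cc1` bears a different set of methoxy groups at both ends of the core. In a functional assay on UO-31 cells (Homo sapiens) for cytotoxicity, read by sulforhodamine B assay, with a stated time of 48 h, tested at 0.01 uM (on this read-out higher numbers stand for a weaker effect at the one concentration tested and lower numbers for a stronger effect), compound 1 gives 91%, the higher of the two numbers measured, and compound 2 gives 86%; the gap between them lies within the usual scatter of the measurement, so the two values show no difference in effect.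

Compound 3 `COc1cc(-c2cc(/C=C/C(=O)c3ccc(Cl)c(Cl)c3)[nH]n2)cc(OC)c1OC` differs from compound 1 in one place: 3,4-dichlorophenyl in place of 4-aminophenyl on a carbonyl carbon. Within the data shown here, no pair of measured compounds shows this change, so there is no measured step to lean on. Both measured values sit at a high percentage, meaning a weak effect at the single concentration tested, and nothing in them points toward a stronger effect. The expectation is therefore that compound 3 stays close to compound 1, with a number 1 percentage points lower from compound 1 to compound 3 (within the scatter) estimated to be none beyond the scatter. Compound 3 is expected to give about 90%, estimated within a range from 72% to 104%.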

Compound 3, a percentage reported as activity, at one concentration (the size of the read-out at that concentration, not a potency): 85%
For compound 3 the middle estimate is 5 percentage points above the measured one; the range from low to high includes it.
By their numbers in this assay, from the lowest: compounds 3, 2 and 1 (each within the scatter of the next).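

In this assay, among these compounds, putting 3,4-dichlorophenyl in place of 4-aminophenyl on the carbonyl carbon gives a number 6 percentage points lower from compound 1 to compound 3 (within the scatter), the first measured step at this position. The two compounds shown earlier differ in more than one place and could not isolate this position, whereas this pair shows that swapping an amine-bearing ring for a chlorine-bearing ring does not separate the two compounds at this single concentration. Nothing measured here offers an explanation for this result, so the reason for it stays unknown.

Going by these compounds, whether a group of another kind on the ring at this carbonyl carbon, such as a carboxylic acid or a nitrile, would stand apart from these two remains open, as does the effect of a longer chain in place of the ring. Because the read-out comes from one low concentration and is not a potency, it also leaves open whether 4-aminophenyl and 3,4-dichlorophenyl would differ at higher concentrations, where the effect might be large enough to compare.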